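The compounds below may be only part of what the source reports. "The series", "measured", "known", "first", "only" and "open" are said of these compounds alone.

Compound 1 `Fc1ccc(F)c(/N=N/Nc2ccccc2)c1` and compound 2 `Fc1ccc(F)c(/N=N/Nc2cccc(C(F)(F)F)c2)c1` share one core, while compound 3 `Cc1c(/N=N/c2cccc(C(F)(F)F)c2)ccc(NC[C@@H]2CCCN3CCCC[C@H]23)c1C` and the unmeasured compound 4 `Cc1c(/N=N/c2ccccc2)ccc(NC[C@@H]2CCCN3CCCC[C@H]23)c1C` share another; the difference between the two cores is not broken down here. All were or will be tested in an ADME assay on BHK-21 cells (Mesocricetus auratus) for cytotoxicity, read by MTT assay, with a stated time of 96 h; a higher number here means that more compound is tolerated, a lower number that less compound is tolerated. Compound 1 gives only a limit of the assay, > 100000 nM. Compound 2 likewise gives only a limit, > 100000 nM. Compound 3 also gives only a limit, >= 100000 nM. The change from compound 2 to compound 1 is hydrogen in place of trifluoromethyl on an aromatic carbon, and the step it made is a step that the two limits leave unreadable from compound 2 to compound 1, because both ends sit at the limit of > 100000 nM in this assay, at which 2 of the 3 values shown sit. The change from compound 3 to compound 4 is hydrogen in place of trifluoromethyl on an aromatic carbon, the same change on the other core. For compound 4 the step in this assay is expected to be a step that the limit leaves unreadable from compound 3 to compound 4, resting on compound 3 sitting at the limit of >= 100000 nM in this assay, at which 1 of the 3 values shown sits, and on the unreadable step that the two limits leave unreadable from compound 2 to compound 1. Compound 4 is therefore estimated to give 150000 nM in this assay, most likely again as a limit rather than a number, within 60000 nM to 400000 nM.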

Compound 4, half-maximal cytotoxic concentration: 47000 nM
Beside the measured number, compound 4's estimate is 3.2-fold (0.50 log units) above it; measured number outside the range, below it.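

In this assay, hydrogen in place of trifluoromethyl on this core gives an at least 2.1-fold lower number from compound 3 to compound 4 (0.32 log units; beyond the scatter), a real change on this one core, with less compound tolerated once the trifluoromethyl group is gone. The true size of this step may be larger, because one end of it is only a limit of the assay: the limit of >= 100000 nM in this assay, at which 1 of the 4 values shown sits. On the core shared by compound 1 and compound 2 the same change cannot be read, so nothing here shows whether the drop carries across from one core to the other, because both of those compounds sit at a limit of the assay: the limit of > 100000 nM in this assay, at which 2 of the 4 values shown sit.

Going by these compounds, it stays open whether a chlorine atom, a methoxy group or a nitrile at the same place on the ring would lower the number as hydrogen does on the core of compound 3. On these data alone, it also stays open whether the change would give a step of similar size on a third core, where both ends could be read as numbers.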